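Moving a trifluoromethyl group on a sulfonyl-linked phenyl ring

The source may hold more compounds than are shown below. What is called first, only, known or untested is meant among the compounds shown, and "the series" means these compounds.

Four compounds share a core in which a hydroxy-bearing chain carries an amide to a pentafluorosulfanyl-substituted phenyl ring. Compound 1 `CC(O)(CSc1ccc(C(F)(F)F)cc1)C(=O)Nc1ccc(S(F)(F)(F)(F)F)cc1` joins a 4-(trifluoromethyl)phenyl to a sulfur whose other neighbours are: saturated chain carbon. In a functional assay on VCaP cells (Homo sapiens) for antiproliferative activity, read by propidium iodide staining, with a stated time of 96 h (a higher number here means a weaker inhibitor, a lower number a stronger inhibitor), compound 1 gives 24800 nM. Compound 2 `CC(O)(CSc1cccc(C(F)(F)F)c1)C(=O)Nc1ccc(S(F)(F)(F)(F)F)cc1` differs by 3-(trifluoromethyl)phenyl in place of 4-(trifluoromethyl)phenyl on a sulfur, and in this assay compound 2 gives 18800 nM. The step of a 1.3-fold lower number from compound 1 to compound 2 (0.12 log units; within the scatter) is small.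

Compound 3 `CC(O)(CS(=O)(=O)c1ccc(C(F)(F)F)cc1)C(=O)Nc1ccc(S(F)(F)(F)(F)F)cc1` carries the same aryl group, but here the sulfur is a sulfonyl sulfur. The difference between the core of compound 3 and that of compound 1 is not broken down here. In this assay compound 3 gives 27700 nM, which sits close to the values of compound 1 and compound 2.

Compound 4 `CC(O)(CS(=O)(=O)c1cccc(C(F)(F)F)c1)C(=O)Nc1ccc(S(F)(F)(F)(F)F)cc1` is not yet measured. It differs from compound 3 by 3-(trifluoromethyl)phenyl in place of 4-(trifluoromethyl)phenyl on a sulfonyl sulfur. This is the same kind of change as that from compound 1 to compound 2; the places differ in that the former sits on a sulfur whose other neighbours are: saturated chain carbon, whereas the latter sits on a sulfonyl sulfur whose other neighbours are: saturated chain carbon. Because the earlier step of a 1.3-fold lower number from compound 1 to compound 2 (0.12 log units; within the scatter) stayed within the scatter, a step of similar size, a 1.3-fold lower number from compound 3 to compound 4 (0.10 log units; within the scatter), is expected for compound 4. Compound 4 is therefore estimated to give 22000 nM in this assay, with a likely range from 12000 nM to 45000 nM.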

Compound 4, half-maximal inhibitory concentration: 32000 nM
Estimate against measurement, compound 4: 1.5-fold (0.16 log units) below, and the stated range covers the measured number.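

In this assay, exchanging 4-(trifluoromethyl)phenyl for 3-(trifluoromethyl)phenyl on a sulfonyl sulfur gives a 1.2-fold higher number from compound 3 to compound 4 (0.06 log units; within the scatter), a step too small to count as a real change. Set beside the same exchange on the plain sulfur of compound 1, the two steps do not differ by more than repeated measurements would: the same change on two cores in this assay, a 1.3-fold lower number (0.12 log units; within the scatter) from compound 1 to compound 2 and a 1.2-fold higher number (0.06 log units; within the scatter) from compound 3 to compound 4, 1.5-fold (0.18 log units) apart, within the scatter of two such steps. This shows that, on these two cores, the exchange stays within the scatter both times, so the two results agree in being small; it does not show that the exchange has a direction that carries from one core to the other, since the two printed steps point opposite ways and neither can be told from noise, and two cores are too few to speak for the whole series.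

The compounds shown leave open whether any other group on this aryl ring, such as a chlorine, a nitrile or an amine in place of the trifluoromethyl group, would give a step beyond the scatter. They also leave open what happens when the hydroxy group or the pentafluorosulfanyl group is replaced, for instance by a hydrogen or a carboxylic acid.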